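The source may report more compounds than this note shows. Statements on the series, on what has been measured and on what is new or still open speak of the compounds shown alone.

Measured so far:
compound 1 `CCCC(=O)Nc1cccc(Oc2cccc(OC)c2)c1` with 26.8 nM
compound 2 `CCCC(=O)Nc1ccc(Oc2cccc(OC)c2)cc1` with 0.75 nM
compound 3 `CCC(=O)Nc1ccc(Oc2cccc(OC)c2)cc1` with 6.8 nM

In an assay on isolated protein for binding affinity to melatonin receptor type 1B (Homo sapiens) (on this read-out lower numbers stand for stronger inhibition and higher numbers for weaker inhibition), compound 2 gives the lowest of the three numbers. Its nearest neighbour is compound 3, reached by a 9.1-fold higher number from compound 2 to compound 3 (0.96 log units; beyond the scatter); compound 1 lies further off, its value shown above. The unmeasured compound 4 `COc1cccc(Oc2ccc(NC(=O)C3CC3)cc2)c1` differs from compound 2 in one place: cyclopropyl in place of propyl on a carbonyl carbon. Among the measured compounds shown here, no measured pair carries exactly this change. The only step that touches the same part of the molecule is the one from compound 2 to compound 3, which shortened the chain on the carbonyl carbon and cost the amount shown above by a 9.1-fold higher number from compound 2 to compound 3 (0.96 log units; beyond the scatter). Here the count of carbon atoms stays the same and only the arrangement changes, so the pattern seen in compound 3 does not apply directly. Compound 4 is therefore expected to move by a 2.0-fold higher number from compound 2 to compound 4 (0.30 log units; within the scatter) at most, a step that may not exceed the scatter. The estimate for compound 4 in this assay is 1.5 nM, in a range from 0.4 nM to 6 nM.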

Compound 4, inhibition constant: 13 nM
For compound 4 the middle estimate is 8.7-fold (0.94 log units) below the measured one; measured number outside the range, above it.
By their numbers in this assay, from the lowest: compound 2; then compounds 3 and 4 (each within the scatter of the next); then compound 1.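

In this assay, replacing propyl with cyclopropyl on the carbonyl carbon leaves the count at 3 heavy atoms, yet it gives a 17-fold higher number from compound 2 to compound 4 (1.24 log units; beyond the scatter), so among these compounds carbon count alone does not set the number at this position. The comparison of the two shorter or ring-closed groups gives a 1.9-fold higher number from compound 3 to compound 4 (0.28 log units; within the scatter), which places cyclopropyl and ethyl together, and of the three groups shown on this carbonyl carbon, only propyl goes with the lowest number. The data shown offer no explanation for the gap between propyl and cyclopropyl.

From the compounds shown here alone, it remains open whether isopropyl, a longer chain such as butyl, or a larger ring such as cyclobutyl on the carbonyl carbon would stay near compound 2 or fall with compound 4. Also unknown is how cyclopropyl would behave on the core of compound 1.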